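This account rests on a few compounds, and the source may have more. Where it says the series, first, only, none or still open, it means among the compounds named here.

Measured in a functional assay on MCF7 cells (Homo sapiens) for inhibition, read by sulforhodamine B assay, with a stated time of 48 h; a higher number here means a weaker inhibitor of growth, a lower number a stronger inhibitor of growth:
compound 1 `O=c1ccoc(/C=C/c2ccccc2)c1` gives 691 uM
compound 2 `O=C1C=CCC(/C=C/c2ccccc2)N1` gives 607 uM
compound 3 `O=C1C=CCC(/C=C/c2ccc(C(F)(F)F)cc2)N1` gives 150 uM

Compound 3 stands lowest of the three numbers in this assay; compound 2 is nearest, compound 1 furthest, both beyond the scatter. Among the measured compounds shown here, the only step between measured compounds that differ in one place is a 4.0-fold lower number from compound 2 to compound 3 (0.61 log units; beyond the scatter), trifluoromethyl in place of hydrogen on an aromatic carbon.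

Compound 4 `COc1ccc(/C=C/C2CC=CC(=O)N2)cc1` differs from compound 3 by methoxy in place of trifluoromethyl on an aromatic carbon. For the measured compounds named here, no measured step shows methoxy against either hydrogen or trifluoromethyl on this ring, so the bearing of the one known step is indirect. Since removing trifluoromethyl would return toward compound 2, compound 4 is expected to give a higher number than compound 3, a step of about a 2.7-fold higher number from compound 3 to compound 4 (0.43 log units; beyond the scatter), partway back. The estimate for compound 4 in this assay is 400 uM, range 150 uM to 1000 uM.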

Compound 4, concentration for growth inhibition (reported as GI): > 1090 uM
Compound 4 gave a limit, no number; the forecaster's own chance of this, stated with the estimate: 10%; middle value at least 2.7-fold (0.43 log units) away from the limit.
By their numbers in this assay, from the lowest: compound 3; then compounds 2 and 1 (each within the scatter of the next). At a limit, above all of these: compound 4.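

In this assay compound 4 reads only as a limit, > 1090 uM, not a number. Methoxy in place of trifluoromethyl on this aromatic carbon gives an at least 7.2-fold higher number from compound 3 to compound 4 (0.86 log units; beyond the scatter). Against hydrogen the change gives an at least 1.7-fold higher number from compound 2 to compound 4 (0.25 log units; that floor lies within the scatter), so methoxy shows none of the drop in the number seen with trifluoromethyl, though its true distance from hydrogen stays unresolved.

Going by these compounds, the true value of compound 4 remains unknown. Open too, on these data alone, is how an amine, a carboxylic acid or a chlorine atom would read on this aromatic carbon, and whether trifluoromethyl's step holds on the core of compound 1.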